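Notes on a hydroxy addition to compound 2

The source may report more compounds than this note shows. Statements on the series, on what has been measured and on what is new or still open speak of the compounds shown alone.

In a functional assay on HeLa cells (Homo sapiens) for cytotoxicity, read by MTT assay, with a stated time of 2 days (a higher number here means a weaker inhibitor, a lower number a stronger inhibitor), compound 1 (`CC(=O)OC[C@H]1O[C@H](O[C@]2(COC(C)=O)O[C@H](CO)[C@@H](O)[C@@H]2OC(=O)/C=C/c2ccc(O)cc2)[C@H](O)[C@@H](OC(C)=O)[C@@H]1O`) gives 1330 nM as its half-maximal inhibitory concentration, and compound 2 (`CC(=O)OC[C@H]1O[C@H](O[C@]2(COC(C)=O)O[C@H](CO)[C@@H](O)[C@@H]2OC(=O)/C=C/c2ccc(O)cc2)[C@H](OC(C)=O)[C@@H](O)[C@@H]1O`) gives 2490 nM on the same read-out. Compound 2 therefore stands within the scatter of compound 1, and the two numbers cannot be ranked.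

Compound 3 (`CC(=O)OC[C@H]1O[C@H](O[C@]2(COC(C)=O)O[C@H](CO)[C@@H](O)[C@@H]2OC(=O)/C=C/c2ccc(O)c(O)c2)[C@H](OC(C)=O)[C@@H](O)[C@@H]1O`) differs from compound 2 by one change (hydroxy in place of hydrogen on an aromatic carbon): hydroxy in place of hydrogen on an aromatic carbon, ortho to a hydroxy group, so that 4-hydroxyphenyl becomes 3,4-dihydroxyphenyl. Among the measured compounds shown here, no measured pair shows this change, so its size cannot be read from the data. With compound 1 at 1330 nM and compound 2 at 2490 nM as the only anchors, only a small shift is expected. A slight drop in the number is expected, and the step of a 1.2-fold lower number from compound 2 to compound 3 (0.10 log units; within the scatter) is estimated to stay within the scatter of this assay rather than beyond it. The estimate for compound 3 is 2000 nM with a range from 800 nM to 5000 nM as the span expected.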

Compound 3, half-maximal inhibitory concentration: 1090 nM
Beside the measured number, compound 3's estimate is 1.8-fold (0.26 log units) above it; low and high end bracket the measured number.
By their numbers in this assay, from the lowest: compounds 3, 1 and 2 (each within the scatter of the next, the first and the last beyond it).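

Compound 2 and compound 3 give the series its first readable step at this position: in this assay, hydroxy in place of hydrogen, turning 4-hydroxyphenyl into 3,4-dihydroxyphenyl, comes with a 2.3-fold lower number from compound 2 to compound 3 (0.36 log units; beyond the scatter). The new hydroxy stands on an aromatic carbon, ortho to a hydroxy group, and the step shows that the read-out responds to a change at this place on the ring, though the size is modest and rests on this single pair. Nothing measured here bears on what lies behind the step.

Among the compounds shown here, this change is seen only with the acetyl groups placed as in compound 2, so whether a step of similar size would appear with the arrangement of compound 1 remains open. Also open, going by these compounds, is whether the step belongs to hydroxy in particular or would also come with another group at this place, such as methoxy, fluorine or an amine, and whether it would hold for a hydroxy group elsewhere on the ring.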